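A few compounds are considered here, and "the series" means these few. Any claim that something is new, unique, unknown or untested is made for them only; others in the source may bear on it.

Series notes. Compound 1 `CC(=O)n1cc(/C=C(/C(=O)O)c2ccc(Cl)cc2)c2cc(OCc3ccccc3)ccc21` gives 52300 nM in a functional assay on A549 cells (Homo sapiens) for cytotoxicity, read by MTT assay, with a stated time of 72 h; on this read-out higher numbers stand for weaker inhibition and lower numbers for stronger inhibition. Compound 2 `CC(=O)n1cc(/C=C(/C(=O)O)c2ccc(OCc3ccccc3)cc2)c2cc(OCc3ccccc3)ccc21` gives 44100 nM, and compound 3 `COc1ccccc1/C(=C\c1cn(C(C)=O)c2ccc(OCc3ccccc3)cc12)C(=O)O` gives 57200 nM. Compound 1 stands second highest of the three numbers shown; nearest to it is compound 3, with a 1.1-fold higher number from compound 1 to compound 3 (0.04 log units; within the scatter), and furthest is compound 2, with a 1.2-fold lower number from compound 1 to compound 2 (0.07 log units; within the scatter).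

Compound 4 `COc1ccc(OC)c(/C(=C\c2cn(C(C)=O)c3ccc(OCc4ccccc4)cc23)C(=O)O)c1` has not been measured. Against compound 1 the change is 2,5-dimethoxyphenyl in place of 4-chlorophenyl on a double-bonded chain carbon bound to a carbonyl carbon and a double-bonded chain carbon. Among the compounds with values here, two measured steps bear on this. The step of a 1.1-fold higher number from compound 1 to compound 3 (0.04 log units; within the scatter) also exchanges the aryl group on the double-bonded chain carbon bound to a carbonyl carbon and a double-bonded chain carbon. The step of a 1.2-fold lower number from compound 1 to compound 2 (0.07 log units; within the scatter) alters a substituent on an aromatic carbon elsewhere in the molecule. Within the data shown here, neither moves the number in this assay beyond the scatter, and no measured step does. The expected step is therefore a 1.1-fold higher number from compound 1 to compound 4 (0.02 log units; within the scatter), nothing beyond the scatter in either direction. The estimate for compound 4 is 55000 nM, with a range from 25000 nM to 120000 nM.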

Compound 4, half-maximal inhibitory concentration: 54500 nM
Beside the measured number, compound 4's estimate is 1.0-fold (0.00 log units) above it; low and high end bracket the measured number.
By their numbers in this assay, from the lowest: compounds 2, 1, 4 and 3 (each within the scatter of the next).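

In this assay, the 2,5-dimethoxyphenyl group is the largest aryl group yet seen on the double-bonded chain carbon bound to a carbonyl carbon and a double-bonded chain carbon, and exchanging 4-chlorophenyl for it still gives only a 1.0-fold higher number from compound 1 to compound 4 (0.02 log units; within the scatter). The series also now has its first step that adds a group to this aryl ring without any other exchange: methoxy in place of hydrogen on an aromatic carbon gives a 1.0-fold lower number from compound 3 to compound 4 (0.02 log units; within the scatter). The data on hand offer no explanation for how little these changes alter the number.

As far as these compounds go, whether any group on this aryl ring can move the number beyond the scatter remains open. A dimethylamino group on that ring, or a methyl ester in place of the carboxylic acid, would be a different kind of change from those shown here.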